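Removing a Methyl Near the Carbonyl: An Expected Stability Drop

A few compounds are considered here, and "the series" means these few. Any claim that something is new, unique, unknown or untested is made for them only; others in the source may bear on it.

Of the compounds shown here, three have so far been measured in an ADME assay on microsomes from liver (Macaca mulatta) for metabolic stability, with a stated time of 0.5 h, tested at 0.5 mg/mL; on this read-out lower numbers stand for a less stable compound and higher numbers for a more stable compound. Compound 1 `CN(C)C(=O)CCNC(=O)c1cc(-c2ccc(F)cc2)no1` gives 10% in this assay. Compound 2 `CC(CNC(=O)c1cc(-c2ccc(F)cc2)no1)C(=O)N(C)C` gives 52% in this assay. Compound 3 `CC(C)C(=O)N1CC2(CC(NC(=O)c3cc(-c4ccccc4)no3)C2)C1` gives 55% in this assay.

Compound 2 and compound 1 differ in a single place: hydrogen in place of methyl on a saturated chain carbon bound to a carbonyl carbon and a saturated chain carbon. That one change produced a number 42 percentage points lower from compound 2 to compound 1 (beyond the scatter). Compound 3 differs from compound 2 in more than one place, and the difference between the two cores is not broken down here. The values of compound 3 and compound 2 lie within the scatter of each other, whereas compound 3 stands beyond the scatter from compound 1.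

Compound 4 `CCC(=O)N1CC2(CC(NC(=O)c3cc(-c4ccccc4)no3)C2)C1` has not yet been measured. It differs from compound 3 by the same change: hydrogen in place of methyl on a saturated chain carbon bound to a carbonyl carbon and a saturated chain carbon. This change therefore appears twice among the four compounds, once with a measured outcome and once without. Among the measured compounds shown here, whether the change acts the same way on the core of compound 3 as on the core of compound 2 is unknown from these data; only one measured step exists. Compound 4 is nevertheless expected to come out lower than compound 3, with an estimated step of a number 27 percentage points lower from compound 3 to compound 4 (beyond the scatter), because the measured pair showed a number 42 percentage points lower from compound 2 to compound 1 (beyond the scatter). Compound 4 is estimated at 28%, expected to fall somewhere between 8% and 50%.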

Compound 4, percent of the compound remaining: 69%
Estimate against measurement, compound 4: 41 percentage points below; the measured number lies above the stated range.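

In this assay, putting hydrogen in place of methyl on a saturated chain carbon bound to a carbonyl carbon and a saturated chain carbon gave a number 14 percentage points higher from compound 3 to compound 4 (beyond the scatter), so on this core the isopropyl to ethyl change raised the number instead of lowering it. Set beside the earlier result, the same change clearly behaved differently on the two cores: the same change on two cores in this assay, a number 42 percentage points lower (beyond the scatter) from compound 2 to compound 1 and a number 14 percentage points higher (beyond the scatter) from compound 3 to compound 4, 56 percentage points apart, beyond the scatter of two such steps. Among the compounds shown here, this shows that, in this series, the direction and size of a step measured on one core cannot simply be carried to another, but it does not show why, as each core offers only one measured pair and the two cores differ in more than one place, leaving unclear which part of them matters.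

The compounds shown leave open what happens when this position carries something other than methyl or hydrogen, such as a longer chain or an amine. They also leave open how the change behaves on further cores, including whether either of the two opposite results seen here is the more common one.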